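The source may hold more compounds than are shown below. What is called first, only, known or untested is meant among the compounds shown, and "the series" means these compounds.

Working notes on the series. Three compounds that share one core have numbers in a functional assay on SK-OV-3 cells (Homo sapiens) for inhibition, read by sulforhodamine B assay, with a stated time of 48 h; on this read-out lower numbers stand for stronger inhibition of growth and higher numbers for weaker inhibition of growth. Compound 1 `Nc1cc(N)c2nc(-c3ccccc3)c(Oc3ccc(Cl)c(Cl)c3)nc2c1` gives 24000 nM, the highest of the three numbers. Compound 2 `Nc1cc(N)c2nc(-c3ccccc3)c(NCc3ccc(Cl)c(Cl)c3)nc2c1` gives 18600 nM, and the gap between compound 1 and compound 2 is within the scatter, so the two are read as alike. Compound 3 `COc1cc(CNc2nc3cc(N)cc(N)c3nc2-c2ccccc2)cc(OC)c1OC` gives 5370 nM, and that gap from compound 1 lies beyond the scatter. Among the measured compounds shown here, no two measured compounds differ in one place only, so no single-point step is on hand to lean on.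

Compound 4 `Nc1cc(N)c2nc(-c3ccccc3)c(Sc3ccc(Cl)c(Cl)c3)nc2c1` is not yet measured. It differs from compound 1 by (3,4-dichlorophenyl)sulfanyl in place of 3,4-dichlorophenoxy on an aromatic carbon. The counted change leaves the ring and the chlorines in place; only the linking atom is exchanged, with the same heavy-atom count and the same donor and acceptor tally on each side.

With no measured step of this kind in the set, the step expected in this assay is estimated at a 1.2-fold lower number from compound 1 to compound 4 (0.08 log units; within the scatter), that is, none beyond the scatter in either direction. The number expected for compound 4 in this assay is accordingly estimated at 20000 nM, with a range from 8000 nM to 50000 nM.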

Compound 4, concentration for 50% growth inhibition: 14800 nM
Compound 4: middle estimate off by 1.4-fold (0.13 log units), on the high side, within the range that was stated.
By their numbers in this assay, from the lowest: compound 3; then compounds 4, 2 and 1 (each within the scatter of the next).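

In this assay, among the compounds shown here, the exchange of 3,4-dichlorophenoxy for (3,4-dichlorophenyl)sulfanyl on the aromatic carbon next to the ring nitrogen is the first single-point step, and it reads as a 1.6-fold lower number from compound 1 to compound 4 (0.21 log units; within the scatter) on this read-out. At this position, ortho to a phenyl group, compound 1 and compound 4 therefore read as alike, and the oxygen link and the sulfur link are not told apart in this assay. No measurement on hand offers an explanation for this result.

From the compounds shown here alone, whether a sulfonyl or a methylene link at the same carbon would also read alike stays open. Also open, going by these compounds, is whether the oxygen and sulfur links would still read alike with an amine or a carboxylic acid on the dichlorophenyl ring.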